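Swapping a Thiazole for a Pyrimidine on the Sulfonamide

A few compounds are considered here, and "the series" means these few. Any claim that something is new, unique, unknown or untested is made for them only; others in the source may bear on it.

Compound 1 `NS(=O)(=O)c1ccc(NC2=NC(=O)/C(=C\c3coc4ccccc4c3=O)S2)cc1` carries an unsubstituted sulfonamide, and in a functional assay on MCF7 cells (Homo sapiens) for cytotoxicity, read by sulforhodamine B assay, with a stated time of 72 h (on this read-out higher numbers stand for weaker inhibition and lower numbers for stronger inhibition), compound 1 gives 8910 nM. Compound 2 `O=C1N=C(Nc2ccc(S(=O)(=O)Nc3nccs3)cc2)S/C1=C/c1coc2ccccc2c1=O` places a 1,3-thiazol-2-yl group on that sulfonamide nitrogen. In this assay compound 2 reaches only a limit, > 100000 nM, so its true value is not known. The step of an at least 11-fold higher number from compound 1 to compound 2 (1.05 log units; beyond the scatter) is therefore a lower bound, set by the limit of > 100000 nM in this assay, at which 1 of the 2 values shown sits. Compound 3 `Cc1cc(C)nc(NS(=O)(=O)c2ccc(NC3=NC(=O)/C(=C\c4coc5ccccc5c4=O)S3)cc2)n1` changes the same position again: 4,6-dimethylpyrimidin-2-yl in place of 1,3-thiazol-2-yl on a sulfonamide nitrogen. For the measured compounds named here, no measured step compares two different groups on that nitrogen, so the only guide is that compound 2 already sits at the limit after substitution. Compound 3 is therefore expected to stay weak, with an estimated step of a number no higher from compound 2 to compound 3 (the limit leaves the size open) and an expected value of 100000 nM, in a range from 20000 nM to 300000 nM.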

Compound 3, half-maximal inhibitory concentration: > 100000 nM
Compound 3 gave a limit, no number; the forecaster's own chance of this, stated with the estimate: 55%; the middle value lies on the limit itself.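

The loss seen with 1,3-thiazol-2-yl is not confined to that ring: 4,6-dimethylpyrimidin-2-yl on the sulfonamide nitrogen also gives an at least 11-fold higher number from compound 1 to compound 3 (1.05 log units; beyond the scatter) in this assay, and this step is only a lower bound. The value of compound 3, > 100000 nM, is a limit and not a number. The step between the two substituted compounds cannot be read, so the five-membered and six-membered rings cannot be ranked, because both compounds stop at the same limit: the limit of > 100000 nM in this assay, at which 2 of the 3 values shown sit.

From the compounds shown here alone, it remains open whether a small group on the sulfonamide nitrogen, such as a methyl or an acetyl, would stay close to compound 1. Also open, going by these compounds, is how much weaker compound 2 and compound 3 truly are.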